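Ester and methyl in place of acid and nitro

The source may hold more compounds than are shown below. What is called first, only, known or untested is meant among the compounds shown, and "the series" means these compounds.

Two members of the series have numbers in an assay on isolated protein for activation of cGMP-dependent protein kinase 1 (Homo sapiens), read by ADP-Glo, with stated times of 30 min and 2 h (on this read-out higher numbers stand for an effect only at larger amounts of compound and lower numbers for an effect already at smaller amounts), so far. Compound 1 `O=C(O)c1ccc(CN2CCC[C@H](O[C@H](CO)c3cc(Cl)cc(Cl)c3)[C@@H]2c2ccccc2)c([N+](=O)[O-])c1` in this assay gives 13000 nM. Compound 2 `Cc1cc(C(=O)O)ccc1CN1CCC[C@H](O[C@@H](CC(C)(C)O)c2cc(Cl)cc(Cl)c2)[C@@H]1c1ccccc1` in this assay gives 8800 nM. The two values lie within the usual scatter of each other, so compound 1 and compound 2 are not separated on the numbers shown; no pair of measured compounds differs in a single place, and no step between measured compounds is available.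

Compound 3 `COC(=O)c1ccc(CN2CCC[C@H](O[C@H](CO)c3cc(Cl)cc(Cl)c3)[C@@H]2c2ccccc2)c(C)c1` is not yet measured. It differs from compound 1 by a group of 11 heavy atoms (9 carbon, 2 oxygen; one six-membered aromatic ring of carbon only) in place of a group of 12 heavy atoms (7 carbon, 1 nitrogen, 4 oxygen; one six-membered aromatic ring of carbon only), on a saturated chain carbon bound to an amine nitrogen in a ring. Among the measured compounds shown here, no measured pair tests a change of this kind, so the expectation rests on the two values alone and on the nature of the exchange.

The step from compound 1 to compound 3 is expected to be a 1.9-fold higher number from compound 1 to compound 3 (0.28 log units; within the scatter), toward a higher number, of a size that may go beyond the scatter. For compound 3 in this assay the estimate is 25000 nM, with a range from 8000 nM to 80000 nM, and a real chance that only a limit is reported.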

Compound 3, half-maximal effective concentration: > 200000 nM
Compound 3 was reported as a limit; the forecaster's own chance of this, stated with the estimate: 35%; middle value at least 8.0-fold (0.90 log units) from the limit.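

In this assay compound 3 gives > 200000 nM, which is a limit of the assay and not a number. Among the compounds shown here, this is the first step between compounds that differ in one place, and it shows that the group on a saturated chain carbon bound to an amine nitrogen in a ring is not a silent position: exchanging 4-carboxy-2-nitrophenyl for the aromatic group bearing a methyl ester and a methyl gives an at least 15-fold higher number from compound 1 to compound 3 (1.18 log units; beyond the scatter), a large change that lies beyond the scatter, whereas the two earlier values could not be separated and offered no step. The true size of this step stays unknown on the high side: the limit of > 200000 nM in this assay, at which 1 of the 3 values shown sits.

The compounds shown leave open how the step divides between the carboxylic acid going to the methyl ester and the nitro group going to methyl, as both changes sit in one exchange. Also open, from the compounds shown here alone, is how a primary amide or a tetrazole in place of the carboxy group would read in this assay.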